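The source may hold more compounds than are shown below. What is called first, only, known or untested is meant among the compounds shown, and "the series" means these compounds.

Measured so far:
compound 1 `COc1cc2c(cc1OC)C(=O)C(CC1CCN(C(=S)Nc3ccccc3)CC1)C2`: 100 mg/kg
compound 2 `COc1cc2c(cc1OC)C(=O)C(CC1CCN(C(=S)Nc3cccc(C)c3)CC1)C2`: "not determined" (no result reported)

In a functional assay on the whole organism (strain Swiss albino) with Mus musculus as the target, with a stated time of 0.5 h (a lower number here means that less compound is needed, a higher number that more compound is needed for the effect), compound 1 gives 100 mg/kg. For the measured compounds named here, compound 2 was also prepared, but in this assay compound 2 gives "not determined" (no result reported), so compound 2 stands nowhere on the scale; the only anchor is compound 1. Compound 3 `COc1cc2c(cc1OC)C(=O)C(CC1CCN(C(=S)Nc3ccc(C)cc3)CC1)C2` differs from compound 2 in one place: 4-methylphenyl in place of 3-methylphenyl on an amide-type nitrogen. With no value for compound 2, no step from compound 2 to compound 3 can be worked out, and nothing among these compounds suggests that exchanging 3-methylphenyl for 4-methylphenyl should carry compound 3 beyond the scatter from compound 1. Compound 3 is therefore expected to give about 100 mg/kg in this assay, estimated to fall between 30 mg/kg and 300 mg/kg.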

Compound 3, minimum effective dose: 100 mg/kg
For compound 3 middle estimate and measured number coincide at the digits printed, and the stated range covers the measured number.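

In this assay, methyl in place of hydrogen on an aromatic carbon gives no change at the digits printed from compound 1 to compound 3 (within the scatter), so 4-methylphenyl on the amide-type nitrogen serves as well as the unsubstituted phenyl of compound 1. On these data alone, compound 2 has no value, so the step to compound 3 cannot be read, and any difference between 3-methylphenyl and 4-methylphenyl remains unknown. No measured information offers an explanation for this result.

The compounds shown leave open whether 4-methoxyphenyl, 4-chlorophenyl or a phenyl ring carrying a longer chain would change the dose needed. They also leave open how a carbonyl in place of the thiocarbonyl would read.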